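Swapping the 4-ethoxyphenyl arm for ethyl in this series

This account rests on a few compounds, and the source may have more. Where it says the series, first, only, none or still open, it means among the compounds named here.

Measured so far:
compound 1 `COc1cc(N)c(Cl)cc1NC(=O)C1CCN(Cc2ccc([N+](=O)[O-])cc2)CC1` — in a functional assay on the whole organism for antagonist activity, with Mus musculus as the target (a higher number here means that more compound is needed for the effect, a lower number that less compound is needed), compound 1 gives > 4 mg/kg, a limit of the assay.
compound 2 `COc1cc(N)c(Cl)cc1NC(=O)C1CCN(CC2CCC2)CC1` — compound 2 gives > 10 mg/kg, a limit of the assay.
compound 3 `CCOc1ccc(CN2CCC(C(=O)Nc3cc(Cl)c(N)cc3OC)CC2)cc1` — compound 3 gives 6.3 mg/kg.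

Among the measured compounds shown here, compound 3 holds the only number in the set; the other two values are limits, as the limit of > 10 mg/kg in this assay, at which 1 of the 3 values shown sits, and the limit of > 4 mg/kg in this assay, at which 1 of the 3 values shown sits, record. Compound 4 `CCCN1CCC(C(=O)Nc2cc(Cl)c(N)cc2OC)CC1` differs from compound 3 by ethyl in place of 4-ethoxyphenyl on a saturated chain carbon bound to an amine nitrogen in a ring. The step that bears on it is an at least 1.5-fold lower number from compound 2 to compound 3 (0.20 log units; that floor lies within the scatter), an alkyl arm giving way to the aryl arm; a step that the limit leaves unreadable from compound 1 to compound 3 and a step that the two limits leave unreadable from compound 1 to compound 2 are unreadable. Returning to a small alkyl, as in compound 2, points toward a higher number, likely again near a limit. For compound 4 the expected value is 12 mg/kg, estimated between 4 mg/kg and 35 mg/kg, which means an expected step of a 1.9-fold higher number from compound 3 to compound 4 (0.28 log units; within the scatter).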

Compound 4, dose for half-maximal effect: > 10 mg/kg
Compound 4: a limit, no number (the forecaster's own chance of this, stated with the estimate: 55%); the middle value does not contradict the limit.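

In this assay the ethyl arm of compound 4 ends at a limit and not a number, as the cyclobutyl arm of compound 2 does. Among the compounds shown here, the one readable step is an at least 1.5-fold higher number from compound 3 to compound 4 (0.20 log units; that floor lies within the scatter), so this floor alone does not separate the ethyl arm from the 4-ethoxyphenyl arm at this place. The steps among compound 1, compound 2 and compound 4 cannot be read, and compound 2 and compound 4 share one limit: the limit of > 10 mg/kg in this assay, at which 2 of the 4 values shown sit.

Open, going by these compounds, is whether any alkyl arm here gives a number in this assay. A longer chain, or a benzyl arm carrying an amine or a carboxylic acid, would test how far the number of compound 3 depends on its aryl arm.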